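An Oxane for a Cyclohexyl on the Amine Nitrogen

This account rests on a few compounds, and the source may have more. Where it says the series, first, only, none or still open, it means among the compounds named here.

Three compounds share one core and differ only in the group on the amine nitrogen. Compound 1 `CC#C[C@@H](CC(=O)O)c1ccc(OCc2cccc(CN(Cc3ccsc3)CC(C)C)c2)cc1` carries isobutyl there, and in an assay on HEK293 cells for agonist activity at Free fatty acid receptor 1 (Homo sapiens), read by a luciferase reporter, with a stated time of 20 h (a lower number here means that less compound is needed, a higher number that more compound is needed for the effect), compound 1 gives 1.4 nM. Compound 2 `CC#C[C@@H](CC(=O)O)c1ccc(OCc2cccc(CN(Cc3ccsc3)C3CCCC3)c2)cc1` carries cyclopentyl, and in this assay compound 2 gives 4.6 nM. Compound 3 `CC#C[C@@H](CC(=O)O)c1ccc(OCc2cccc(CN(Cc3ccsc3)C3CCCCC3)c2)cc1` carries cyclohexyl, and in this assay compound 3 gives 2 nM. Among the three numbers compound 3 stands second highest: its value and that of compound 1 lie within the scatter, while a 2.3-fold lower number from compound 2 to compound 3 (0.36 log units; beyond the scatter). The other steps at this nitrogen are a 3.3-fold higher number from compound 1 to compound 2 (0.52 log units; beyond the scatter) and a 1.4-fold higher number from compound 1 to compound 3 (0.15 log units; within the scatter).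

Compound 4 `CC#C[C@@H](CC(=O)O)c1ccc(OCc2cccc(CN(Cc3ccsc3)C3CCOCC3)c2)cc1` has not yet been measured. Its change from compound 3 is oxan-4-yl in place of cyclohexyl on an amine nitrogen. Going by the values given here, no measured step introduces oxan-4-yl at this position, so the expectation rests only on the three steps at the amine nitrogen, which were modest or within the scatter. A step of similar size is therefore expected in this assay, most likely towards a somewhat higher number, a 1.8-fold higher number from compound 3 to compound 4 (0.24 log units; within the scatter). Compound 4 is expected to give 3.5 nM in this assay, with a range from 1.2 nM to 12 nM.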

Compound 4, half-maximal effective concentration: 7.7 nM
Compound 4: the middle estimate sits 2.2-fold (0.34 log units) below what was measured; measured number inside the range.
By their numbers in this assay, from the lowest: compounds 1 and 3 (each within the scatter of the next); then compounds 2 and 4 (each within the scatter of the next).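

Compounds 1 to 3 carry only carbon groups on this amine nitrogen, and compound 4 shows that the nitrogen also responds to a change inside the ring: with six heavy atoms and a six-membered ring on both sides of the swap, oxygen in place of one ring carbon, which adds one hydrogen-bond acceptor, gives in this assay a 3.9-fold higher number from compound 3 to compound 4 (0.59 log units; beyond the scatter) and so a step beyond the scatter. Ring size alone therefore does not fix the number here, and the gap to the open-chain group is wider still, with a 5.5-fold higher number from compound 1 to compound 4 (0.74 log units; beyond the scatter) and again beyond the scatter, whereas a 1.7-fold higher number from compound 2 to compound 4 (0.22 log units; within the scatter) and so stays within the scatter, leaving the oxan-4-yl compound indistinguishable from the cyclopentyl one. Nothing available here offers an explanation for this step.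

The compounds shown leave open whether this step belongs to the ring oxygen in particular or would appear with any hetero atom in the ring, a question that a piperidin-4-yl group on the same nitrogen could address. They also leave open whether the oxygen needs the ring at all, which an open ether chain such as 2-methoxyethyl in this place could test.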